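The compounds below may be only part of what the source reports. "The series", "measured", "known", "first", "only" and "open" are said of these compounds alone.

Compound 1 `CC(C)[C@H](NC(=O)CCN(C)C)c1cccc(F)c1N1CCN(C(=O)[C@@H]2CN(C(C)C)C[C@H]2c2ccc(C(F)(F)F)c(F)c2)CC1`: 47%
Compound 2 `Cc1ccc(N2CCN(C(=O)[C@@H]3CN(C4CCOCC4)C[C@H]3c3ccc(Cl)cc3)CC2)c([C@@H](NC(=O)CCN)C(C)C)c1`: 107%

Both compounds were measured in a functional assay on CHO cells with Melanocortin receptor 4 (Homo sapiens) as the target, read by cAMP accumulation; on this read-out higher numbers stand for larger maximal responses and lower numbers for smaller maximal responses. Of the two, compound 2 gives the higher reading, 107%, while compound 1 gives the lower one, 47%, a gap well beyond the usual scatter. Within the data shown here, no pair among the measured compounds differs in only one place, so the two readings stand side by side without a single-change comparison between them.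

Compound 3 `CNCC(=O)N[C@H](c1cc(C)ccc1N1CCN(C(=O)[C@@H]2CN(C3CCOCC3)C[C@H]2c2ccc(Cl)cc2)CC1)C(C)C` has not yet been measured in this assay. It differs from compound 2 in one spot: methylamino in place of aminomethyl on a saturated chain carbon bound to a carbonyl carbon. The two have the same atoms, joined differently. Among the measured compounds shown here, with no measured step of this kind to lean on, the expected change is a number 7 percentage points lower from compound 2 to compound 3 (within the scatter), a shift not larger than the scatter in either direction. Compound 3 is therefore estimated at 100%, with a range from 80% to 115%.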

Compound 3, intrinsic activity: the largest response reached, in percent of the reference agonist's: 84%
Beside the measured number, compound 3's estimate is 16 percentage points above it; the measured number falls inside the stated range.
By their numbers in this assay, from the lowest: compound 1; then compound 3; then compound 2.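

Swapping aminomethyl for methylamino on a saturated chain carbon bound to a carbonyl carbon gives a number 23 percentage points lower from compound 2 to compound 3 (beyond the scatter) in this assay, the first single-change comparison among these compounds. The two groups have the same heavy atoms, the same hydrogen-bond donor and acceptor counts and no net charge, so how those atoms are joined at this place is enough to shift the maximal response. Nothing available here explains why the reading falls.

Still open, going by these compounds, is how a (dimethylamino)methyl group, a longer amine chain or a carboxylic acid would read at this place. It is also unknown whether the same swap would shift the response similarly on a different set of substituents, such as those of compound 1.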